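Swapping pentyloxy for 8-acetamidooctyl on the chain

This account rests on a few compounds, and the source may have more. Where it says the series, first, only, none or still open, it means among the compounds named here.

- Compound 1 `COCCCCCCCCCCCCCCC/C=C1/CC(CO)(COC(=O)C(C)(C)C)OC1=O`: < 0.1 ug/mL (a limit of the assay, not a number)
- Compound 2 `CCCCCCCCC(O)CCCCCC/C=C1\CC(CO)(COC(=O)C(C)(C)C)OC1=O`: 5.72 ug/mL
- Compound 3 `CCCCCOCCCCCCC/C=C1\CC(CO)(COC(=O)C(C)(C)C)OC1=O`: 0.877 ug/mL

In a functional assay on CCRF-CEM cells (Homo sapiens) for antiproliferative activity (a higher number here means a weaker inhibitor of growth, a lower number a stronger inhibitor of growth), only two of these results are true numbers, and compound 3 has the lower one at 0.877 ug/mL. Compound 2 stands higher, at 5.72 ug/mL.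

Compound 4 `CC(=O)NCCCCCCCCCCCCCCC/C=C1\CC(CO)(COC(=O)C(C)(C)C)OC1=O` has not yet been measured. It differs from compound 3 by one change in the chain: 8-acetamidooctyl in place of pentyloxy on a saturated chain carbon, seven bonds along the chain from a double-bonded chain carbon.

Within the data shown here, only one measured step bears on this change: a 6.5-fold lower number from compound 2 to compound 3 (0.81 log units; beyond the scatter). It is also a swap within the chain, and it shows that such a swap can shift the result in this assay by a modest amount. It involves different groups, so it is only a rough guide. A step of similar or smaller size is therefore expected, and since compound 3 has the lower number, a move upward seems more likely than a move downward.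

The expected change is a 2.9-fold higher number from compound 3 to compound 4 (0.45 log units; beyond the scatter).

For compound 4, the estimated value is 2.5 ug/mL, with an expected range from 0.5 ug/mL to 12 ug/mL.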

Compound 4, concentration for 50% growth inhibition: 1.08 ug/mL
Estimate against measurement, compound 4: 2.3-fold (0.36 log units) above; low and high end bracket the measured number.
By their numbers in this assay, from the lowest: compounds 3 and 4 (each within the scatter of the next); then compound 2. At a limit, below all of these: compound 1.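

In this assay, placing 8-acetamidooctyl in place of pentyloxy on a saturated chain carbon, seven bonds along the chain from a double-bonded chain carbon, gives a 1.2-fold higher number from compound 3 to compound 4 (0.09 log units; within the scatter) and so leaves the two results indistinguishable. Among these compounds, the one earlier step, a 6.5-fold lower number from compound 2 to compound 3 (0.81 log units; beyond the scatter), showed that a swap within the chain can move the number, whereas this swap brings in 12 heavy atoms in place of 6, plus a hydrogen-bond donor, with no change beyond the scatter. Nothing given here accounts for why the two results match.

The compounds shown leave open whether an amine or a carboxylic acid in this part of the chain would also leave the number in place. Among the compounds shown here, compound 1 gives < 0.1 ug/mL as a limit of the assay, not a number, and no step from it can be read.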